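A few compounds are considered here, and "the series" means these few. Any claim that something is new, unique, unknown or untested is made for them only; others in the source may bear on it.

Measured so far:
compound 1, `CC1=C(/C=C/C(=O)/C=C/c2ccccc2)C(C)(C)CCC1`, giving 10600 nM in a functional assay on MCF7 cells (Homo sapiens) for cytotoxicity, read by sulforhodamine B assay, with a stated time of 48 h; on this read-out higher numbers stand for weaker inhibition and lower numbers for stronger inhibition;
compound 2, `CC1=C(/C=C/C(=O)/C=C/c2ccc(F)cc2)C(C)(C)CCC1`, giving 6200 nM in this assay.

Among the compounds with values here, compound 2 carries the lowest of the two numbers, but its only neighbour is compound 1, and the move a 1.7-fold lower number from compound 1 to compound 2 (0.23 log units; within the scatter) stays within the scatter, so the two compounds cannot be told apart on this read-out.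

The next compound, compound 3, `CC1=C(/C=C/C(=O)/C=C/c2ccc(C#N)cc2)C(C)(C)CCC1`, keeps the shared core and the chain of compound 2 and changes only the group on the ring at the far end: cyano in place of fluoro on an aromatic carbon.

Within the data shown here, only one measured step touches the same ring position, the fluoro for hydrogen exchange a 1.7-fold lower number from compound 1 to compound 2 (0.23 log units; within the scatter), and it did not move the number beyond the scatter. Nothing measured here shows a cyano group, so the expectation rests on that single small step alone. In this assay a step of about a 1.0-fold lower number from compound 2 to compound 3 (0.01 log units; within the scatter) is therefore expected, which is no change beyond the scatter in either direction.

Compound 3 is thus estimated at 6000 nM in this assay, within a range from 2500 nM to 14000 nM.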

Compound 3, half-maximal inhibitory concentration: 13200 nM
Estimate against measurement, compound 3: 2.2-fold (0.34 log units) below; measured number inside the range.
By their numbers in this assay, from the lowest: compounds 2, 1 and 3 (each within the scatter of the next, the first and the last beyond it).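

This ring position, on an aromatic carbon para to a large group, now gives its first step beyond the scatter in this assay, where cyano in place of fluoro produces a 2.1-fold higher number from compound 2 to compound 3 (0.33 log units; beyond the scatter) as a modest move. Cyano in place of hydrogen at the same carbon produces a 1.2-fold higher number from compound 1 to compound 3 (0.10 log units; within the scatter) and stays within the scatter, so compound 1 cannot be told apart from either compound 2 or compound 3, and only the two substituted compounds separate from each other. Nothing available here explains why the cyano and fluoro compounds differ.

Going by these compounds, what a methoxy group, a chlorine atom, an amine or a carboxylic acid would do at this carbon remains open, including whether any of them would move the number beyond the scatter from compound 1, the compound with hydrogen there. On these data alone, it is also open whether the gap between fluoro and cyano would hold with either group placed elsewhere on the ring, or with the shared core changed.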